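Moving a fluorine on the benzyl group of compound 3

The source may report more compounds than this note shows. Statements on the series, on what has been measured and on what is new or still open speak of the compounds shown alone.

Of the compounds shown here, three on one shared core have been measured in an assay on FRT cells for positive allosteric modulation of Cystic fibrosis transmembrane conductance regulator variant N1303K (Homo sapiens), in the presence of a further agent that is not named here; a higher number here means that more compound is needed for the effect, a lower number that less compound is needed. Compound 1 `COc1ccc2[nH]c3c(c2c1)CCNC31CCN(Cc2cc(Cl)ccc2[N+](=O)[O-])CC1` gives 7100 nM. Compound 2 `COc1ccc2[nH]c3c(c2c1)CCNC31CCN(Cc2c(F)ccc(Cl)c2F)CC1` gives 1500 nM. Compound 3 `COc1ccc2[nH]c3c(c2c1)CCNC31CCN(Cc2ccc(F)cc2F)CC1` gives 2000 nM. Compound 3 stands second highest of these three numbers: against compound 2 the difference is a 1.3-fold higher number from compound 2 to compound 3 (0.12 log units; within the scatter), and against compound 1 it is a 3.6-fold lower number from compound 1 to compound 3 (0.55 log units; beyond the scatter).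

Compound 4 `COc1ccc2[nH]c3c(c2c1)CCNC31CCN(Cc2ccc(F)c(F)c2)CC1` differs from compound 3 by 3,4-difluorophenyl in place of 2,4-difluorophenyl on a saturated chain carbon bound to an amine nitrogen in a ring. For the measured compounds named here, the measured steps that bear on this are a 4.7-fold lower number from compound 1 to compound 2 (0.68 log units; beyond the scatter) and a 3.6-fold lower number from compound 1 to compound 3 (0.55 log units; beyond the scatter), both modest and both removing the nitro group, whereas the only step that keeps a fluorinated benzyl group, a 1.3-fold higher number from compound 2 to compound 3 (0.12 log units; within the scatter), lies within the scatter. Rearranging the two fluorines, with nothing added or removed, is therefore expected to give no step beyond the scatter in this assay in either direction. Compound 4 is estimated at 2000 nM, within a range of 900 nM to 4500 nM. The step this estimate implies, no change at the digits printed from compound 3 to compound 4 (within the scatter), is expected to stay within the scatter.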

Compound 4, half-maximal effective concentration: 11000 nM
Compound 4: middle estimate off by 5.5-fold (0.74 log units), on the low side; the measured number lies above the stated range.
By their numbers in this assay, from the lowest: compounds 2 and 3 (each within the scatter of the next); then compounds 1 and 4 (each within the scatter of the next).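

On the saturated chain carbon bound to an amine nitrogen in a ring, the same two fluorines in a new arrangement give a 5.5-fold higher number from compound 3 to compound 4 (0.74 log units; beyond the scatter) in this assay, so this place responds to where the fluorines sit and not only to which atoms are present. The fluorinated benzyl groups therefore no longer form one group: the series shows a 7.3-fold higher number from compound 2 to compound 4 (0.87 log units; beyond the scatter) and also a 1.5-fold higher number from compound 1 to compound 4 (0.19 log units; within the scatter), which places the 3,4-difluorobenzyl group of compound 4 with the nitro-bearing group of compound 1 rather than with compounds 2 and 3. Nothing available here accounts for this shift.

Which single fluorine carries the shift remains open, and a 2-fluorophenyl or 4-fluorophenyl group would separate the two. A plain phenyl or a pyridyl ring at this place would show whether fluorine is needed at all.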